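Swapping the sulfonyl aryl group in a weakly active flavone-like series

The source may hold more compounds than are shown below. What is called first, only, known or untested is meant among the compounds shown, and "the series" means these compounds.

The shared core carries an ester in compound 1 `COC(=O)c1cc(=O)c2c(OC)cc(OC)cc2[nH]1`, which in a functional assay on SUP-B15 cells (Homo sapiens) for antiproliferative activity, with a stated time of 72 h (a lower number here means that less compound is needed, a higher number that more compound is needed for the effect), gives 16100 nM. Compound 2 `COc1ccc(-c2cc(=O)c3c(OC)cc(OC)cc3n2S(=O)(=O)c2ccc(C)c([N+](=O)[O-])c2)cc1` instead bears a methoxyphenyl on the core and a 4-methyl-3-nitrophenyl on a sulfonyl sulfur attached to the aromatic nitrogen. In this assay compound 2 reaches only a limit, > 51700 nM, so no number is known for it; (the limit of > 51700 nM in this assay, at which 1 of the 2 values shown sits). Compound 3 `COc1ccc(-c2cc(=O)c3c(OC)cc(OC)cc3n2S(=O)(=O)c2ccc(Br)cc2)cc1` keeps everything else and changes (4-bromophenyl in place of 4-methyl-3-nitrophenyl on a sulfonyl sulfur). Going by the values given here, no step between measured compounds is available, so the size of this change can only be expected, not read off. Because compound 2 sits at the limit > 51700 nM, compound 3 is expected to stay weak as well, with the step from the limit to the estimate, an at least 1.0-fold lower number from compound 2 to compound 3 (0.01 log units; that floor lies within the scatter), taken as no change beyond the scatter. Compound 3 is thus estimated at 50000 nM, in a range from 15000 nM to 160000 nM.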

Compound 3, half-maximal effective concentration: 63800 nM
The estimate for compound 3 lay 1.3-fold (0.11 log units) below the measured number; low and high end bracket the measured number.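

No step from compound 2 to compound 3 can be read in this assay, because compound 2 has no number, only a limit: the limit of > 51700 nM in this assay, at which 1 of the 3 values shown sits.

The compounds shown leave open which of the two groups on the sulfonyl sulfur, 4-bromophenyl or 4-methyl-3-nitrophenyl, gives the lower number.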